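This account rests on a few compounds, and the source may have more. Where it says the series, first, only, none or still open, it means among the compounds named here.

Compound 1 `CCCSc1nc(N/N=C/c2ccc(C)cc2)c2nnn(Cc3ccccc3)c2n1` in a functional assay on MCF7 cells (Homo sapiens) for antiproliferative activity, read by MTT assay, with a stated time of 72 h (a lower number here means a stronger inhibitor, a higher number a weaker inhibitor), gives > 64000 nM, which is a limit of the assay and not a number.
Compound 2 `COc1cc(/C=N/Nc2nc(SCc3ccccc3)nc3c2nnn3Cc2ccccc2)cc(OC)c1OC` gives 13500 nM in this assay.
Compound 3 `CCCSc1nc(N/N=C(\C)c2ccccc2O)c2nnn(Cc3ccc(F)cc3)c2n1` gives > 64000 nM in this assay, again a limit rather than a number.

Among the three measured compounds, compound 1 stands at the limit of > 64000 nM in this assay, at which 2 of the 3 values shown sit, so no number is known for it, and it cannot be ranked against compound 3, whose value is the same limit. Compound 2 alone yields a measured number, and it sits a good way below that limit.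

Compound 4 `CCCSc1nc(N/N=C/c2ccc(Br)cc2)c2nnn(Cc3ccccc3)c2n1` differs from compound 1 in one place: bromo in place of methyl on an aromatic carbon. For the measured compounds named here, no measured pair in this set carries the same change, so its effect in this assay is not yet known from these data. The small size of the swap, one heavy atom for one heavy atom at the same place on the ring, gives no ground for expecting a step beyond the scatter in either direction.

Compound 4 is therefore expected to give about 70000 nM, within a range from 20000 nM to 200000 nM, which would mean an estimated step that the limit leaves unreadable from compound 1 to compound 4 from compound 1 to compound 4, most likely reported again only as a limit.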

Compound 4, half-maximal inhibitory concentration: > 64000 nM
Compound 4: only a limit was reported; the forecaster's own chance of this, stated with the estimate: 70%; the middle value does not contradict the limit.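

Compound 1 and compound 4 both reach only a limit and not a number in this assay, so no step can be read between them: the limit of > 64000 nM in this assay, at which 3 of the 4 values shown sit. The compounds shown leave open what bromo in place of methyl does on a compound that gives a measured number.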